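This account rests on a few compounds, and the source may have more. Where it says the series, first, only, none or still open, it means among the compounds named here.

Compound 3 `Cc1cc(=O)n(-c2cccc(F)c2)nc1C(=O)Nc1ccc(Oc2ncnc3[nH]ccc23)c(F)c1` stands second highest of the three numbers in a functional assay on A549 cells (Homo sapiens) for cytotoxicity, read by MTT assay, with a stated time of 72 h (a higher number here means a weaker inhibitor, a lower number a stronger inhibitor), giving 31500 nM; compound 2 `Cc1cc(=O)n(-c2ccc(F)cc2)nc1C(=O)Nc1ccc(Oc2ncnc3[nH]ccc23)c(F)c1` gives 42400 nM, and compound 1 `Cc1ccc(-n2nc(C(=O)Nc3ccc(Oc4ncnc5[nH]ccc45)cc3)c(C)cc2=O)cc1` gives 6400 nM. Compound 4 `Cc1ccc(-n2nc(C(=O)Nc3ccc(Oc4ncnc5[nH]ccc45)c(F)c3)c(C)cc2=O)cc1` differs from compound 3 by 4-methylphenyl in place of 3-fluorophenyl on an aromatic nitrogen. Among the measured compounds shown here, no measured step makes exactly this change. For the measured compounds named here, the one step at the same position, a 1.3-fold lower number from compound 2 to compound 3 (0.13 log units; within the scatter), only exchanged one fluorophenyl for another. Compound 1 carries the 4-methylphenyl, yet it also differs from compound 3 in a second place, so its lower number cannot be credited to that group alone. The step expected for compound 4 is therefore a modest one, a 2.6-fold lower number from compound 3 to compound 4 (0.42 log units; beyond the scatter), with wide uncertainty. Compound 4 is estimated at 12000 nM, between 4000 nM and 36000 nM.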

Compound 4, half-maximal inhibitory concentration: 18500 nM
Estimate against measurement, compound 4: 1.5-fold (0.19 log units) below; the range from low to high includes it.
By their numbers in this assay, from the lowest: compound 1; then compounds 4, 3 and 2 (each within the scatter of the next, the first and the last beyond it).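

The change on the aromatic nitrogen proves small in one comparison, with 4-methylphenyl in place of 3-fluorophenyl giving a 1.7-fold lower number from compound 3 to compound 4 (0.23 log units; within the scatter). Methyl in place of fluoro on that same phenyl ring gives a modest but clearer step, a 2.3-fold lower number from compound 2 to compound 4 (0.36 log units; beyond the scatter). The 4-methylphenyl does not by itself account for the low number of compound 1, since fluoro in place of hydrogen on an aromatic carbon of the core gives a 2.9-fold higher number from compound 1 to compound 4 (0.46 log units; beyond the scatter). No measurement shown explains any of these steps. On these data alone, how an amine, a carboxylic acid or a longer chain on the aromatic nitrogen would compare stays open.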